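A few compounds are considered here, and "the series" means these few. Any claim that something is new, unique, unknown or untested is made for them only; others in the source may bear on it.

Measured so far in a functional assay on the whole organism for inhibition, with Rattus norvegicus as the target, at a dose of 10 mg/kg by the oral route; on this read-out higher numbers stand for more inhibition at the one dose given (going by the name of the read-out) and lower numbers for less inhibition:
compound 1 `COc1cccc([C@H]2O[C@H](CC(=O)N3CCC(CC(=O)O)CC3)C(=O)N(CC(C)(C)COC(=O)C(C)C)c3ccc(Cl)cc32)c1OC`: 34%
compound 2 `COc1cccc([C@H]2O[C@H](CC(=O)NCC(=O)O)C(=O)N(CC(C)(C)CO)c3ccc(Cl)cc32)c1OC`: 14%
compound 3 `COc1cccc([C@H]2O[C@H](CC(=O)N3CCC(CC(=O)O)CC3)C(=O)N(CC(C)(C)COCC(=O)OC(C)(C)C)c3ccc(Cl)cc32)c1OC`: 43%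

Compound 2 stands lowest of the three; compound 1 lies beyond the scatter above it, and compound 3 further still. Compound 4 `COc1cccc([C@H]2O[C@H](CC(=O)N3CCC(CCC(=O)O)CC3)C(=O)N(CC(C)(C)CO)c3ccc(Cl)cc32)c1OC` is not yet measured. It differs from compound 2 by 4-(2-carboxyethyl)piperidin-1-yl in place of (carboxymethyl)amino on a carbonyl carbon.

Within the data shown here, the only single-place step measured, a number 9 percentage points higher from compound 1 to compound 3 (within the scatter), concerns the group on the oxygen of the saturated carbon, not the amide, so it does not bear directly on this change. Compounds 1 and 3 do carry a piperidin-1-yl amide in place of the (carboxymethyl)amino of compound 2, and both give numbers beyond the scatter above compound 2; but each also differs from compound 2 on the oxygen, so their values are only a loose pointer.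

On that pointer an upward step is expected, a number 16 percentage points higher from compound 2 to compound 4 (beyond the scatter). Compound 4 is estimated at 30% in this assay, with a range of 10% to 50%.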

Compound 4, a percentage reported as inhibition, in the whole organism at one dose (the size of the read-out at that dose, not a potency): 76%
Beside the measured number, compound 4's estimate is 46 percentage points below it; the whole stated range lies below it.
By their numbers in this assay, from the lowest: compound 2; then compounds 1 and 3 (each within the scatter of the next); then compound 4.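

In this assay the change on the carbonyl carbon gives a number 62 percentage points higher from compound 2 to compound 4 (beyond the scatter) with the rest of the molecule unchanged, so this place alone can carry a large step at the one dose given. Compounds 1 and 3 could not show this, since each also differs from compound 2 on the oxygen. Nothing available accounts for the size of the step.

Going by these compounds, the step brings in the six-membered ring and the carboxyethyl chain together, so the share of each stays open, and 4-(carboxymethyl)piperidin-1-yl on the core of compound 4 would separate them. Also open, on these data alone, is how a longer chain, as in 4-(3-carboxypropyl)piperidin-1-yl, or a tetrazole in place of the carboxylic acid, would read at this place.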